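Notes on isobutyl in place of methoxy

The compounds below may be only part of what the source reports. "The series", "measured", "known", "first", "only" and "open" are said of these compounds alone.

Among the measured compounds shown here, compound 3 `COc1ccc(-c2c(C)[nH]c(=O)n2C2CCCCC2)cc1` stands second highest of the three numbers so far in a functional assay on brain (Rattus norvegicus, strain Wistar) for inhibition; a higher number here means a weaker inhibitor, a lower number a stronger inhibitor: compound 3 gives 20400 nM, compound 2 `CCCCOc1ccc(-c2c(C)[nH]c(=O)n2C2CCCCC2)cc1` gives 13900 nM and compound 1 `Cc1[nH]c(=O)n(C2CCCCC2)c1-c1ccccc1` gives 47600 nM. One gap is a 1.5-fold higher number from compound 2 to compound 3 (0.17 log units; within the scatter), so those two cannot be told apart; the other gap is a 2.3-fold lower number from compound 1 to compound 3 (0.37 log units; beyond the scatter).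

Compound 4 `Cc1[nH]c(=O)n(C2CCCCC2)c1-c1ccc(CC(C)C)cc1` has not been measured in this assay. Its change from compound 3: isobutyl in place of methoxy on an aromatic carbon.

For the measured compounds named here, two measured steps bear on it. Methoxy on the aromatic carbon of compound 1 gave a 2.3-fold lower number from compound 1 to compound 3 (0.37 log units; beyond the scatter), and butoxy on the same carbon gave a 3.4-fold lower number from compound 1 to compound 2 (0.53 log units; beyond the scatter), while going from butoxy back to methoxy gave only a 1.5-fold higher number from compound 2 to compound 3 (0.17 log units; within the scatter). Both substituted compounds thus sit below compound 1 by a modest step, and the longer chain did not add to that beyond the scatter. Going by the values given here, no measured step exchanges an alkoxy group for an alkyl group, so the expectation is a step in this assay of at most modest size, toward a lower number or none beyond the scatter. Compound 4 is expected to give 12000 nM, between 5000 nM and 30000 nM, which is an expected step of a 1.7-fold lower number from compound 3 to compound 4 (0.23 log units; within the scatter).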

Compound 4, half-maximal inhibitory concentration: 10900 nM
Beside the measured number, compound 4's estimate is 1.1-fold (0.04 log units) above it; the range from low to high includes it.
By their numbers in this assay, from the lowest: compounds 4, 2 and 3 (each within the scatter of the next); then compound 1.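

In this assay, isobutyl, with 0 hydrogen-bond acceptors, cannot be told apart at this aromatic carbon from either alkoxy group: the steps (a 1.9-fold lower number from compound 3 to compound 4 (0.27 log units; within the scatter)) and (a 1.3-fold lower number from compound 2 to compound 4 (0.11 log units; within the scatter)) both lie within the scatter. The oxygen of methoxy and butoxy is therefore not required for the modest drop seen on substituting this carbon, since the step (a 4.4-fold lower number from compound 1 to compound 4 (0.64 log units; beyond the scatter)) lies beyond the scatter, and compounds 2, 3 and 4 all give lower numbers than compound 1. Nothing available explains why these three groups cannot be separated here.

The compounds shown leave open whether an amine or a carboxylic acid on this aromatic carbon would keep the number below that of compound 1, since every substituent so far is an alkyl or alkoxy group. They also leave open whether a chain longer than butoxy would separate itself from compound 3 by a step beyond the scatter, or whether the modest gain from substitution at this carbon is already the full extent of the effect.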